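From a free phenol to a 3,4-dimethoxyphenyl group

A few compounds are considered here, and "the series" means these few. Any claim that something is new, unique, unknown or untested is made for them only; others in the source may bear on it.

Measured so far in a functional assay on MDA-MB-231 cells (Homo sapiens) for antiproliferative activity, read by MTT assay, with a stated time of 48 h; on this read-out higher numbers stand for weaker inhibition of growth and lower numbers for stronger inhibition of growth:
compound 1 `CCOC(=O)N1N=C(c2ccccc2)CC1c1cc(OC)c(OC)c(OC)c1` gives 5610 nM
compound 2 `COC(=O)N1N=C(c2cccc(O)c2)CC1c1cc(OC)c(OC)c(OC)c1` gives 740 nM
compound 3 `CCOc1cccc(C2=NN(C(=O)OC)C(c3cc(OC)c(OC)c(OC)c3)C2)c1` gives 190 nM

Compound 3 has the lowest number of the three, and its gaps to compound 1 and compound 2 both lie beyond the scatter. The next compound, compound 4 `COC(=O)N1N=C(c2ccc(OC)c(OC)c2)CC1c1cc(OC)c(OC)c(OC)c1`, has not yet been measured. It differs from compound 3 as follows: 3,4-dimethoxyphenyl in place of 3-ethoxyphenyl on a carbon with a double bond to nitrogen. In words, it has 3,4-dimethoxyphenyl in place of 3-ethoxyphenyl on a carbon with a double bond to nitrogen.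

Going by the values given here, only one measured step bears on this change: a 3.9-fold lower number from compound 2 to compound 3 (0.59 log units; beyond the scatter), with ethyl in place of hydrogen on an oxygen on an aromatic ring. Among the compounds with values here, compound 1 differs from the others in more than one place, so it gives no single step. Compound 4 has no free hydroxyl, so it is not expected to fall back fully to the level of compound 2 at 740 nM. The expected change in this assay is modest and toward a higher number: a 1.8-fold higher number from compound 3 to compound 4 (0.27 log units; within the scatter). Compound 4 is estimated at 350 nM, with an expected range of 90 nM to 1400 nM.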

Compound 4, concentration for 50% growth inhibition: 9900 nM
Beside the measured number, compound 4's estimate is 28-fold (1.45 log units) below it; measured number outside the range, above it.
By their numbers in this assay, from the lowest: compound 3; then compound 2; then compounds 1 and 4 (each within the scatter of the next).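

Going by these compounds alone, the position is far less tolerant than the earlier compounds suggested: in this assay, 3,4-dimethoxyphenyl in place of 3-ethoxyphenyl gives a 52-fold higher number from compound 3 to compound 4 (1.72 log units; beyond the scatter). The same group in place of 3-hydroxyphenyl gives a 13-fold higher number from compound 2 to compound 4 (1.13 log units; beyond the scatter), so removing the free hydroxyl does not by itself lead to a lower number, and the gain seen with the ethyl group does not carry over to this pair of methoxy groups. No evidence is available to explain this loss.

The compounds shown leave open whether the loss follows from the added oxygen-bearing group or from ethoxy giving way to methoxy, a question that 3-methoxyphenyl and 4-methoxyphenyl groups would bear on. They also leave open how an amine such as 3-aminophenyl, or a longer chain such as 3-propoxyphenyl, would behave on this carbon.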